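A few compounds are considered here, and "the series" means these few. Any claim that something is new, unique, unknown or untested is made for them only; others in the source may bear on it.

Notes on the series around the core of compound 1 `Cc1cc(NC(=O)Nc2ccccc2N)c2ccccc2n1`. In a physicochemical assay for solubility, at pH 7.4 (a lower number here means a less soluble compound, a higher number a more soluble compound), compound 1 gives 51800 nM, compound 2 `Cc1cc(NC(=O)Nc2cccc(C(F)(F)F)c2)c2ccccc2n1` gives 100 nM and compound 3 `Cc1cc(NC(=O)Nc2ncccc2C)c2ccccc2n1` gives 1300 nM. Compound 3 therefore holds the middle place of the three numbers, with compound 1 above it and compound 2 below it.

Compound 4 `Cc1cc(NC(=O)Nc2cccc(Cl)c2)c2ccccc2n1` is not yet measured. It carries 3-chlorophenyl in place of 3-methylpyridin-2-yl on an amide-type nitrogen.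

For the measured compounds named here, the only measured step at this place is a 40-fold lower number from compound 1 to compound 3 (1.60 log units; beyond the scatter), which is large and shows that the number can move far when this group changes. It does not give the direction for the new change. Compound 2, at 100 nM, has a six-membered aromatic ring of carbon only on this nitrogen, as compound 4 does, and serves as the closer guide. Compound 1, at 51800 nM, also has such a ring and goes against any rule based on that ring alone, so the range stays wide.

A moderate fall in this assay is expected. The expected step is a 5.9-fold lower number from compound 3 to compound 4 (0.77 log units; beyond the scatter). For compound 4 the estimated value is 220 nM, with an expected range of 70 nM to 700 nM.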

Compound 4, solubility: 800 nM
The estimate for compound 4 lay 3.6-fold (0.56 log units) below the measured number, and the stated range ends below it.
By their numbers in this assay, from the lowest: compound 2; then compounds 4 and 3 (each within the scatter of the next); then compound 1.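

In this assay, a 1.6-fold lower number from compound 3 to compound 4 (0.21 log units; within the scatter) shows that replacing 3-methylpyridin-2-yl with 3-chlorophenyl on the amide-type nitrogen, and with it losing the ring hetero atom and the hydrogen-bond acceptor, gives no change that can be told from the scatter in this pair. The other two steps show that a six-membered aromatic ring of carbon only does not fix the number: an 8.0-fold higher number from compound 2 to compound 4 (0.90 log units; beyond the scatter) comes from chloro in place of trifluoromethyl on an aromatic carbon alone, and a 65-fold lower number from compound 1 to compound 4 (1.81 log units; beyond the scatter) separates 3-chlorophenyl from 2-aminophenyl, so the group carried on that ring matters more here than the ring's hetero atom. No supporting data bear on the reason for any of these steps.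

Compound 1 at 51800 nM is the only one with an amine on this ring, so these compounds cannot tell whether the high number belongs to 2-aminophenyl alone or would carry over to other groups on an aromatic carbon, such as a dimethylamino group or a carboxylic acid. Also open, as far as these compounds go, is whether a pyridine ring without the methyl group would keep the number of compound 3 at 1300 nM.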